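A Methyl Group Added to Three Weak Inhibitors

This account rests on a few compounds, and the source may have more. Where it says the series, first, only, none or still open, it means among the compounds named here.

Measured so far, in an assay on isolated protein for inhibition of Phenylethanolamine N-methyltransferase (Bos taurus); on this read-out lower numbers stand for stronger inhibition and higher numbers for weaker inhibition:
- compound 1, `CCCCCC(O)CN`, gives 314000 nM
- compound 2, `CCCCCCC(C#N)O[Si](C)(C)C`, gives 109000 nM
- compound 3, `CCCCCCCC(C#N)O[Si](C)(C)C`, gives 216000 nM

All three numbers are large, so none of the compounds inhibits strongly. Compound 2 and compound 3 share a core and differ in one place: methyl in place of hydrogen on a saturated chain carbon, seven bonds along the chain from an oxygen on an unsaturated carbon and a triple-bonded carbon. In this assay that change made a 2.0-fold higher number from compound 2 to compound 3 (0.30 log units; within the scatter). Compound 1 has a different core from compound 2, and the difference between the two cores is not broken down here; what the values show is that compound 1 gives a higher number than compound 2, a gap that is beyond the scatter, while compound 1 and compound 3 lie within the scatter of each other.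

Compound 4, `CCCCCC(C)(O)CN`, has not yet been measured. It differs from compound 1 in methyl in place of hydrogen on a saturated chain carbon bound to an oxygen on a saturated carbon and two saturated chain carbons. Among the measured compounds shown here, this is the same kind of change as the one from compound 2 to compound 3, but not the same: there the methyl entered on a saturated chain carbon seven bonds along the chain from an oxygen on an unsaturated carbon and a triple-bonded carbon, here it enters on a saturated chain carbon bound to an oxygen on a saturated carbon and two saturated chain carbons. For the measured compounds named here, the only guide is the earlier step, which was small, so from compound 1 to compound 4 a step of about a 1.4-fold higher number from compound 1 to compound 4 (0.16 log units; within the scatter) is expected because the one measured methyl addition gave a 2.0-fold higher number from compound 2 to compound 3 (0.30 log units; within the scatter). On that basis compound 4 is estimated at 450000 nM in this assay, with a likely range from 150000 nM to 1300000 nM.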

Compound 4, half-maximal inhibitory concentration: 669000 nM
Compound 4: the middle estimate sits 1.5-fold (0.17 log units) below what was measured; measured number inside the range.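

In this assay putting methyl in place of hydrogen on a saturated chain carbon bound to an oxygen on a saturated carbon and two saturated chain carbons gave a 2.1-fold higher number from compound 1 to compound 4 (0.33 log units; beyond the scatter) and so made compound 4 a modestly weaker inhibitor than compound 1. Set beside the earlier methyl addition on the other core, the two steps are close in size, and the gap between them does not exceed the scatter, even though only the newer step is itself beyond the scatter: the same change on two cores in this assay, a 2.0-fold higher number (0.30 log units; within the scatter) from compound 2 to compound 3 and a 2.1-fold higher number (0.33 log units; beyond the scatter) from compound 1 to compound 4, 1.1-fold (0.03 log units) apart, within the scatter of two such steps.
This shows that on these two cores the change came out at about the same size, although the methyl entered at a different place on each, but two pairs of weak inhibitors cannot show that the same size would hold on further cores, nor can they explain why the numbers differ.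

As far as these compounds go, whether an ethyl group or a fluorine on the same carbon would give a step of similar size remains open. So does the size of the methyl step on the core of compound 1 with a longer chain, or on a core that carries a carboxylic acid.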